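Swapping the tail substituent for phenyl in a sulfonamide series

The compounds below may be only part of what the source reports. "The series", "measured", "known", "first", "only" and "open" are said of these compounds alone.

Measured compounds:
Compound 1, `O=S(=O)(NCCCNCc1ccc(Cl)cc1)c1cc(C(F)(F)F)cc(C(F)(F)F)c1`, 1600 nM.
Compound 2, `CC(C)(C)c1ccc(CNCCCNS(=O)(=O)c2cc(C(F)(F)F)cc(C(F)(F)F)c2)cc1`, 1400 nM.
Compound 3, `O=S(=O)(NCCCNCc1ccc(C(F)(F)F)cc1)c1cc(C(F)(F)F)cc(C(F)(F)F)c1`, 1700 nM.

All three share one core and differ only in the group on the far aromatic ring. In a functional assay on BXPC-3 cells (Homo sapiens) for inhibition, read by MTT assay, with a stated time of 72 h (a higher number here means a weaker inhibitor of growth, a lower number a stronger inhibitor of growth), compound 3 gives the highest of the three numbers, yet its neighbours lie close: a 1.1-fold higher number from compound 1 to compound 3 (0.03 log units; within the scatter) and a 1.2-fold higher number from compound 2 to compound 3 (0.08 log units; within the scatter), so the three are indistinguishable within the scatter.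

Compound 4 is `O=S(=O)(NCCCNCc1ccc(-c2ccccc2)cc1)c1cc(C(F)(F)F)cc(C(F)(F)F)c1`. It differs from compound 3 in one place: phenyl in place of trifluoromethyl on an aromatic carbon. For the measured compounds named here, the steps that bear on this are those that change the same position, a 1.1-fold lower number from compound 1 to compound 2 (0.06 log units; within the scatter), a 1.1-fold higher number from compound 1 to compound 3 (0.03 log units; within the scatter) and a 1.2-fold higher number from compound 2 to compound 3 (0.08 log units; within the scatter), all within the scatter. Going by the values given here, a phenyl here is larger than any group tried, and no measured step covers such a change, so the expectation rests on the position having tolerated three different groups without a shift beyond the scatter. Compound 4 is therefore expected to show a 1.1-fold lower number from compound 3 to compound 4 (0.05 log units; within the scatter) in this assay, with an estimated value of 1500 nM, between 600 nM and 4000 nM.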

Compound 4, concentration for 50% growth inhibition: 1700 nM
The estimate for compound 4 lay 1.1-fold (0.05 log units) below the measured number; the range from low to high includes it.
By their numbers in this assay, from the lowest: compounds 2, 1, 3 and 4 (each within the scatter of the next).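

In this assay, for the compounds shown here, the new group is the first at this position to bring a ring of its own, yet the number hardly responds: no change at the digits printed from compound 3 to compound 4 (within the scatter), alongside a 1.2-fold higher number from compound 2 to compound 4 (0.08 log units; within the scatter) and a 1.1-fold higher number from compound 1 to compound 4 (0.03 log units; within the scatter). Chloro, tert-butyl, trifluoromethyl and now phenyl therefore cannot be told apart in this assay, so adding an aromatic ring here neither clearly helps nor clearly harms growth inhibition. No measurement offered here explains why the number stays so level across these four groups.

From the compounds shown here alone, all four groups carry no hydrogen-bond donors or charge in the pieces compared so far, so it remains open whether an amine or a carboxylic acid at this position would shift the number beyond the scatter. A plain hydrogen there, with no substituent at all, also remains an open comparison.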